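The compounds below may be only part of what the source reports. "The series", "measured", "known", "first", "only" and "open" are said of these compounds alone.

Measured in an ADME assay on HeLa cells (Homo sapiens) for cytotoxicity, read by MTT assay, with a stated time of 24 h; on this read-out higher numbers stand for weaker inhibition and lower numbers for stronger inhibition:
- compound 1 `CN1CCN(C(=S)SC(=S)N(C)C)CC1`: 1220000 nM
- compound 2 `CCOC(=O)N1CCN(C(=S)SC(=S)N(C)C)CC1`: 530000 nM
- compound 3 `CCSC(=S)N1CCN(C(=S)SC(=S)N(C)C)CC1`: 4480000 nM

Compound 3 stands highest of the three numbers in this assay: a 3.7-fold higher number from compound 1 to compound 3 (0.56 log units; beyond the scatter) and an 8.5-fold higher number from compound 2 to compound 3 (0.93 log units; beyond the scatter), both beyond the scatter.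

Compound 4 `CN(C)C(=S)SC(=S)N1CCN(C(=S)NC2CCCCC2)CC1` differs from compound 3 in one place: cyclohexylamino in place of ethylsulfanyl on a thiocarbonyl carbon. For the measured compounds named here, no measured step touches the thiocarbonyl carbon; all three known steps alter the group on the ring amine nitrogen, where a 2.3-fold lower number from compound 1 to compound 2 (0.36 log units; beyond the scatter), a 3.7-fold higher number from compound 1 to compound 3 (0.56 log units; beyond the scatter) and an 8.5-fold higher number from compound 2 to compound 3 (0.93 log units; beyond the scatter) were modest and ran in both directions. Going by the values given here, the exchange in compound 4 therefore has no direct precedent, and the measured steps only suggest that single-group changes on this scaffold move the number modestly rather than strongly.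

A modest step is thus expected for a 2.2-fold lower number from compound 3 to compound 4 (0.35 log units; beyond the scatter), with a lean toward a lower number because compound 3 already sits at 4480000 nM, the top of the observed range. The estimate for compound 4 in this assay is 2000000 nM, with a range from 600000 nM to 6000000 nM.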

Compound 4, half-maximal inhibitory concentration: > 5000000 nM
Compound 4: only a limit was reported; the forecaster's own chance of this, stated with the estimate: 20%; middle value at least 2.5-fold (0.39 log units) from the limit.
By their numbers in this assay, from the lowest: compound 2; then compound 1; then compound 3. At a limit, above all of these: compound 4.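

In this assay, compound 4 is reported only as a limit, not as a number: the limit of > 5000000 nM in this assay, at which 1 of the 4 values shown sits. This is the first change shown on the thiocarbonyl carbon, and cyclohexylamino in place of ethylsulfanyl gives an at least 1.1-fold higher number from compound 3 to compound 4 (0.04 log units; that floor lies within the scatter). The number does not come down with this exchange, although the entering group brings a six-membered ring and a hydrogen-bond donor, but the floor of the step does not separate the two compounds.

On these data alone, the true size of the step remains open, including whether it exceeds the scatter. As far as these compounds go, it is also open whether an open-chain amine such as butylamino, or a smaller one such as methylamino, would behave like cyclohexylamino on this carbon, which would tell the ring apart from the nitrogen.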